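From Amide Back to Ester: Estimating Compound 3

A few compounds are considered here, and "the series" means these few. Any claim that something is new, unique, unknown or untested is made for them only; others in the source may bear on it.

compound 1 `CC1=C(C(=O)OC(C)(C)C)C(c2cccs2)NC(=O)N1`: 26%
compound 2 `CC1=C(C(=O)NC(C)C)C(c2cccs2)NC(=O)N1`: 2%

In an assay on membranes from CHO cells for displacement of a labelled ligand from adenosine receptor A1 (Homo sapiens), read by scintillation counting, with a stated time of 60 min, tested at 1 uM (on this read-out lower numbers stand for less inhibition and higher numbers for more inhibition at the one concentration tested (going by the name of the read-out)), compound 2 gives 2%, the lowest of the two numbers; compound 1 gives 26%. Compound 3 `CCC(C)OC(=O)C1=C(C)NC(=O)NC1c1cccs1` differs from compound 2 by sec-butoxy in place of isopropylamino on a carbonyl carbon. Among the compounds with values here, the only measured step that bears on this change is a number 24 percentage points lower from compound 1 to compound 2 (beyond the scatter), which ran in the opposite direction, so the present step is expected to recover most of that loss. Compound 3 is therefore expected to rise by a number 20 percentage points higher from compound 2 to compound 3 (beyond the scatter), landing near 22%, with a range from 5% to 40%.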

Compound 3, a percentage reported as inhibition, at one concentration (the size of the read-out at that concentration, not a potency): 5%
Compound 3: middle estimate off by 17 percentage points, on the high side, within the range that was stated.
By their numbers in this assay, from the lowest: compounds 2 and 3 (each within the scatter of the next); then compound 1.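

In this assay, putting sec-butoxy in place of isopropylamino on a carbonyl carbon gives a number 3 percentage points higher from compound 2 to compound 3 (within the scatter), so the oxygen link alone does not separate these two compounds. The difference lies instead in the group on that oxygen: sec-butyl in place of tert-butyl gives a number 21 percentage points lower from compound 1 to compound 3 (beyond the scatter). Nothing available explains this difference. The compounds shown leave open whether tert-butylamino on the same carbonyl carbon would match tert-butoxy or stay with isopropylamino. They also leave open how methoxy or a carboxylic acid there would read.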